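Methyl in Place of Chloro: Expected Plasma Exposure

The compounds below may be only part of what the source reports. "The series", "measured", "known", "first", "only" and "open" are said of these compounds alone.

Of the compounds shown here, three sharing one core have been measured in an ADME assay on the whole organism (strain Zucker) for pharmacokinetics, with Rattus norvegicus as the target, with a stated time of 14 days, at a dose of 3 mg/kg by the oral route; a higher number here means more compound in the circulation at the dose given, a lower number less compound in the circulation. Compound 1 `Cc1ccc(Oc2ccc3nc(COc4cccc(C(=O)O)c4)n(C)c3n2)cc1` gives 1310 nM in this assay. Among the compounds with values here, compound 2 `Cn1c(COc2cccc(C(=O)O)c2)nc2ccc(Oc3ccc4c(c3)OCC4)nc21` gives 1510 nM, and the single measured step, a 1.2-fold higher number from compound 1 to compound 2 (0.06 log units; within the scatter), lies within the scatter. Compound 3 `Cn1c(COc2cccc(C(=O)O)c2)nc2ccc(Oc3ncc(Cl)cc3Cl)cc21` gives 293 nM, the lowest of the three numbers; its gaps to compound 1 and to compound 2 are both beyond the scatter.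

Compound 4 `Cc1cc(Cl)cnc1Oc1ccc2nc(COc3cccc(C(=O)O)c3)n(C)c2c1` differs from compound 3 by methyl in place of chloro on an aromatic carbon. Within the data shown here, no measured step bears on this change: the only step recorded, from compound 1 to compound 2, alters the aryl group on the ether oxygen, not a substituent on the pyridin-2-yl ring, and was within the scatter. With nothing directly comparable, the step of a 1.5-fold higher number from compound 3 to compound 4 (0.19 log units; within the scatter) is expected to be small, with a modest rise considered somewhat more likely than a fall. For compound 4 the maximal plasma concentration in this assay is therefore estimated at 450 nM, within a range from 150 nM to 1400 nM.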

Compound 4, maximal plasma concentration in the Rattus norvegicus assay: 283 nM
Beside the measured number, compound 4's estimate is 1.6-fold (0.20 log units) above it; the measured number falls inside the stated range.
By their numbers in the Rattus norvegicus assay, from the lowest: compounds 4 and 3 (each within the scatter of the next); then compounds 1 and 2 (each within the scatter of the next).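

Within the data shown here, in the Rattus norvegicus assay, compound 3 gives 293 nM and compound 4 gives 283 nM; methyl in place of chloro on this aromatic carbon, ortho to a large group and two atoms from the ring nitrogen, gives a step within the scatter (a 1.0-fold lower number from compound 3 to compound 4 (0.02 log units; within the scatter)), the first reading of a substituent at this position rather than a change of the whole aryl group on the ether oxygen. In a physicochemical assay for lipophilicity, read by LC-MS, in phosphate buffer, measured as octanol-water partition, with a stated time of 30 min, at pH 7.4, tested at 200 mM (a lower number here means a more polar compound, a higher number a more lipophilic compound), compound 3 gives 1.9 and compound 4 gives 1.8; the same exchange also stays within the scatter (a number 0.10 log units lower from compound 3 to compound 4 (within the scatter)), so at this position neither read-out separates methyl from chloro. Nothing measured here offers an explanation for either result.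

The compounds shown leave open whether an amine, a methoxy group or a longer chain on this carbon would move either number beyond the scatter. They also leave open what exchanging the remaining chloro group would do.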